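Closing the amine tail of compound 3 into a ring

The source may report more compounds than this note shows. Statements on the series, on what has been measured and on what is new or still open speak of the compounds shown alone.

Compound 3 `CN(C)CCn1nc(Cc2ccc(Cl)cc2)c2ccccc2c1=O` gives 158 nM in an assay for binding affinity to Alpha-1A adrenergic receptor (Homo sapiens) (a higher number here means a weaker inhibitor, a lower number a stronger inhibitor), the lowest of the two numbers in hand; compound 1 `CN1CCC[C@@H]1Cn1nc(Cc2ccc(O)cc2)c2ccccc2c1=O` stands nearest with 251 nM. Compound 2 `CN1CCC[C@@H]1Cn1nc(CC2CCCCC2)c2ccccc2c1=O` is reported as > 1990 nM, which is a limit of the assay rather than a number. Within the data shown here, the one measured step, an at least 7.9-fold higher number from compound 1 to compound 2 (0.89 log units; beyond the scatter), concerns the 4-hydroxyphenyl and does not touch the amine tail. Compound 4 `CN1CCCC1CCn1nc(Cc2ccc(Cl)cc2)c2ccccc2c1=O` differs from compound 3 by 1-methylpyrrolidin-2-yl in place of dimethylamino on a saturated chain carbon, two bonds along the chain from an aromatic nitrogen. Among the measured compounds shown here, no measured step bears on this change; compound 1 carries the same 1-methylpyrrolidin-2-yl group and sits near compound 3. Compound 4 is therefore expected to show a 1.3-fold higher number from compound 3 to compound 4 (0.10 log units; within the scatter), nothing beyond the scatter. The estimate for compound 4 is 200 nM, between 60 nM and 700 nM.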

Compound 4, inhibition constant: 316 nM
Estimate against measurement, compound 4: 1.6-fold (0.20 log units) below; measured number inside the range.
By their numbers in this assay, from the lowest: compounds 3, 1 and 4 (each within the scatter of the next). At a limit, above all of these: compound 2.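

In this assay the change from dimethylamino to 1-methylpyrrolidin-2-yl gives a 2.0-fold higher number from compound 3 to compound 4 (0.30 log units; within the scatter). This place, two bonds along the chain from an aromatic nitrogen, therefore carries a five-membered non-aromatic ring in the amine tail with no shift beyond the scatter. Nothing shown gives a reason for this step. The compounds shown leave open how a primary amine would read at this place, and whether a longer chain to the amine would leave the number within the scatter.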